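Fluoro in place of nitro: notes on a flat series

This account rests on a few compounds, and the source may have more. Where it says the series, first, only, none or still open, it means among the compounds named here.

In a functional assay, read by spectrophotometry, with a stated time of 20 min (on this read-out higher numbers stand for weaker inhibition and lower numbers for stronger inhibition), compound 1 (`Cc1c(-c2ccccc2)oc2ccccc2c1=O`) gives 106 ug/mL and compound 2 (`COc1ccc(-c2oc3ccccc3c(=O)c2C)cc1`) gives 100 ug/mL on the same read-out. Compound 3 (`Cc1c(-c2ccc([N+](=O)[O-])cc2)oc2ccccc2c1=O`) gives 132 ug/mL and so stands within the scatter of both. The next change leads to compound 4 (`Cc1c(-c2ccc(F)cc2)oc2ccccc2c1=O`), with fluoro in place of nitro on an aromatic carbon, para to a large group (fluoro in place of nitro on an aromatic carbon). Going by the values given here, three measured steps bear on it: methoxy in place of hydrogen (a 1.1-fold lower number from compound 1 to compound 2 (0.03 log units; within the scatter)), nitro in place of hydrogen (a 1.2-fold higher number from compound 1 to compound 3 (0.10 log units; within the scatter)) and nitro in place of methoxy (a 1.3-fold higher number from compound 2 to compound 3 (0.12 log units; within the scatter)). All three lie within the scatter. Among the compounds with values here, no fluoro compound has been measured yet, so the expectation rests on these steps alone. No change beyond the scatter is expected in this assay in either direction, and the estimated step is small (a 1.2-fold lower number from compound 3 to compound 4 (0.07 log units; within the scatter)). For compound 4 the estimated value is 112 ug/mL with an expected range from 70 ug/mL to 175 ug/mL in these units.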

Compound 4, half-maximal inhibitory concentration: 114 ug/mL
Compound 4: middle estimate off by 1.0-fold (0.01 log units), on the low side; the range from low to high includes it.
By their numbers in this assay, from the lowest: compounds 2, 1, 4 and 3 (each within the scatter of the next).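

Fluoro on this aromatic carbon, para to a large group, reads level with all three earlier compounds in this assay (a 1.2-fold lower number from compound 3 to compound 4 (0.06 log units; within the scatter); a 1.1-fold higher number from compound 2 to compound 4 (0.06 log units; within the scatter); a 1.1-fold higher number from compound 1 to compound 4 (0.03 log units; within the scatter)). The heavy atoms and hydrogen-bond acceptors that leave with the nitro produce no step beyond the scatter, and hydrogen, methoxy, nitro and fluoro at this position now all read alike. No measurement at hand bears on the reason for this flatness.

On these data alone, whether an amine, a carboxylic acid or a longer chain on this carbon would break the flat pattern stays open, as does the behaviour of these groups elsewhere on the core of compound 1. With every step inside the scatter, the compounds shown also do not tell which part of the shared core, if any, carries the inhibition.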